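Swapping a Phenylethyl for a Pyridinyl on the Amine

This account rests on a few compounds, and the source may have more. Where it says the series, first, only, none or still open, it means among the compounds named here.

Compound 2 `C[C@H](NCC1CCN(CCCc2c[nH]c3ccc(-n4cnnc4)cc23)CC1)c1ccccc1` and compound 1 `O=S(=O)(NCC1CCN(CCCc2c[nH]c3ccc(-n4cnnc4)cc23)CC1)c1ccccc1` share a core and differ only in the group on an amine nitrogen. In an assay on CHO cells for displacement of a labelled ligand from 5-hydroxytryptamine receptor 1B (Homo sapiens) (a higher number here means a weaker inhibitor, a lower number a stronger inhibitor), compound 1 gives 60 nM and compound 2 gives 58 nM, so the step of a 1.0-fold lower number from compound 1 to compound 2 (0.01 log units; within the scatter) left the two within the scatter of each other. Compound 3 `c1ccc(NCC2CCN(CCCc3c[nH]c4ccc(-n5cnnc5)cc34)CC2)nc1` carries pyridin-2-yl in place of 1-phenylethyl on an amine nitrogen. Among the measured compounds shown here, the single measured step bears on this only loosely: one exchange of the amine substituent left the number unchanged, so no step beyond the scatter is expected here either. Compound 3 is therefore estimated to give 65 nM in this assay, with a range from 20 nM to 220 nM. The expected step is a 1.1-fold higher number from compound 2 to compound 3 (0.05 log units; within the scatter).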

Compound 3, half-maximal inhibitory concentration: 3.3 nM
Estimate against measurement, compound 3: 20-fold (1.29 log units) above, outside the stated range (below it).
By their numbers in this assay, from the lowest: compound 3; then compounds 2 and 1 (each within the scatter of the next).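

In this assay the group on this amine nitrogen proves to matter, since pyridin-2-yl gives an 18-fold lower number from compound 2 to compound 3 (1.24 log units; beyond the scatter) and an 18-fold lower number from compound 1 to compound 3 (1.26 log units; beyond the scatter). The earlier exchange of phenylsulfonyl for 1-phenylethyl therefore did not show that this position tolerates any change without effect. Nothing shown here explains the gain.

The change brings in a ring nitrogen and removes the defined stereocentre together, so the compounds shown cannot separate the two. A plain phenyl or a pyridin-3-yl group on the same amine nitrogen would help to tell them apart.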